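This account rests on a few compounds, and the source may have more. Where it says the series, first, only, none or still open, it means among the compounds named here.

Compound 3 `CCCCCCc1cn(Cc2cc(=O)oc3cc(O)ccc23)nn1` is one of three measured compounds built on the shared core. In a functional assay on CFPAC-1 cells (Homo sapiens) for inhibition, read by MTT assay, with a stated time of 72 h (on this read-out lower numbers stand for stronger inhibition and higher numbers for weaker inhibition), compound 3 gives > 100000 nM, which is a limit of the assay rather than a number. Compound 1 `O=c1cc(Cn2cc(C3CC3)nn2)c2ccc(O)cc2o1` gives > 100000 nM in this assay, also a limit. Compound 2 `O=c1cc(Cn2cc(CCCCO)nn2)c2ccc(O)cc2o1` gives > 100000 nM in this assay, again a limit. In short, (the limit of > 100000 nM in this assay, at which 3 of the 3 values shown sit). The unmeasured compound 4 `O=c1cc(Cn2cc(-c3cc(F)cc(F)c3)nn2)c2ccc(O)cc2o1` differs from compound 3 by 3,5-difluorophenyl in place of hexyl on an aromatic carbon. The steps a step that the two limits leave unreadable from compound 1 to compound 3 and a step that the two limits leave unreadable from compound 2 to compound 3 touch the same position, yet neither can be read, since every value sits at the limit. Going by the values given here, no measured step supplies a direction or size. Compound 4 is therefore expected to give 150000 nM (range 30000 nM to 600000 nM) in this assay, most probably once more as a limit. That expectation corresponds to a step that the limit leaves unreadable from compound 3 to compound 4.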

Compound 4, half-maximal inhibitory concentration: > 100000 nM
Compound 4: no number, only a limit (the forecaster's own chance of this, stated with the estimate: 80%); the middle value is on the limit's open side.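

Going by these compounds alone, compound 4 also gives only a limit, so no step from compound 1, compound 2 or compound 3 to compound 4 can be read: the limit of > 100000 nM in this assay, at which 4 of the 4 values shown sit. The compounds shown leave open whether any group at this aromatic carbon gives a measurable value.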